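The compounds below may be only part of what the source reports. "The series", "measured", "known", "first", "only" and "open" are said of these compounds alone.

Measured so far:
Compound 1 `C=C[C@@](C)(/C=C/c1ccc(O)cc1)CC/C=C/C(=O)OCC` — in a functional assay on HepG2 cells (Homo sapiens) for cytotoxicity, with a stated time of 72 h (a higher number here means that more compound is needed for the effect, a lower number that less compound is needed), compound 1 gives > 52000 nM, which is a limit of the assay and not a number.
Compound 2 `C=C[C@@](C)(/C=C/c1ccc(O)cc1)CC/C=C/C#N` — compound 2 gives > 52000 nM, again a limit.
Compound 3 `COc1ccc(/C=C/[C@@](C)(/C=C/c2ccc(O)c(/C=C/C#N)c2)CCC=C(C)C)cc1` — compound 3 gives > 26000 nM, also a limit.

Among the compounds with values here, the only single change that can be compared directly is the one from compound 2 to compound 1, namely (ethoxycarbonyl in place of cyano on a double-bonded chain carbon bound to a double-bonded chain carbon). Its size is a step that the two limits leave unreadable from compound 2 to compound 1, since both values sit at the limit of > 52000 nM in this assay, at which 2 of the 3 values shown sit, and neither compound reached a measurable effect. How the core of compound 3 differs from the core of compound 2 is not broken down here.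

Compound 4 `CCOC(=O)/C=C/c1cc(/C=C/[C@](C)(/C=C/c2ccc(OC)cc2)CCC=C(C)C)ccc1O` has not yet been measured. It differs from compound 3 by ethoxycarbonyl in place of cyano on a double-bonded chain carbon bound to a double-bonded chain carbon, the same change already seen from compound 2 to compound 1. In this assay the step from compound 3 to compound 4 is expected to be a step that the limit leaves unreadable from compound 3 to compound 4, resting on compound 3 sitting at the limit of > 26000 nM in this assay, at which 1 of the 3 values shown sits, and on the earlier step being unreadable. For compound 4 the estimate is therefore 40000 nM, expected somewhere between 15000 nM and 120000 nM, and most likely reported again only as a limit.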

Compound 4, half-maximal effective concentration: > 52000 nM
Compound 4: no number, only a limit; the forecaster's own chance of this, stated with the estimate: 80%; at least 1.3-fold (0.11 log units) between middle value and limit.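

No step can be read between compound 3 and compound 4 in this assay: both values are limits of the assay and not numbers. The compounds shown leave open how much of any of them is needed for the effect, and whether ethoxycarbonyl in place of cyano changes that amount at all.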